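Hydroxybutynyl thioether series: a chloro replacement on the shared core

The source may report more compounds than this note shows. Statements on the series, on what has been measured and on what is new or still open speak of the compounds shown alone.

Compound 3, `OCC#CCSc1cnc2ccccc2c1[Se]CC#CCCl`, is one of two compounds in this series that in a functional assay on SW707 cells (Homo sapiens) for antiproliferative activity, with a stated time of 72 h (a lower number here means a stronger inhibitor, a higher number a weaker inhibitor), give the lowest numbers: compound 3 gives 3.3 ug/mL. Compound 1, `ClCC#CCSc1cnc2ccccc2c1Cl`, in this assay gives 3.3 ug/mL, no change from compound 3 at the digits printed. Among the measured compounds shown here, compound 2, `OCC#CCSc1cnc2ccccc2c1SCC#CCCl`, gives 19.8 ug/mL, and the one step measured, a 6.0-fold lower number from compound 2 to compound 3 (0.78 log units; beyond the scatter), is a modest one and lies beyond the scatter.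

Compound 4, `OCC#CCSc1cnc2ccccc2c1Cl`, differs from compound 3 by one chlorine atom in place of a group of 6 heavy atoms (4 carbon, 1 chlorine, 1 selenium; no ring), on an aromatic carbon. For the measured compounds named here, no measured step bears directly on this change: the step from compound 2 to compound 3 swaps sulfur for selenium inside the chain and does not remove it. What the numbers show is that compound 1, which carries chloro on the same carbon, sits at the low end of the series, while compound 2 with its hydroxyl chain sits at the high end. Compound 4 combines the hydroxyl chain of compound 2 with the chloro of compound 1, so a small to modest upward step is expected, a 2.4-fold higher number from compound 3 to compound 4 (0.38 log units; beyond the scatter), with the direction uncertain. For compound 4 the estimate in this assay is 8 ug/mL, expected to fall between 2.5 ug/mL and 25 ug/mL.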

Compound 4, concentration for 50% inhibition: 6.2 ug/mL
The estimate for compound 4 lay 1.3-fold (0.11 log units) above the measured number; the measured number falls inside the stated range.
By their numbers in this assay, from the lowest: compounds 1, 3 and 4 (each within the scatter of the next); then compound 2.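

At the aromatic carbon opposite the ring nitrogen, chloro in place of the selenium-bearing group of 6 heavy atoms gives a 1.9-fold higher number from compound 3 to compound 4 (0.27 log units; within the scatter) in this assay, so the whole selenium-bearing chain can go without a change beyond the scatter, whereas the same chloro in place of the sulfur-bearing group gives a 3.2-fold lower number from compound 2 to compound 4 (0.50 log units; beyond the scatter), which places the sulfur-bearing group alone, among the groups shown at this carbon, at a clear distance from chloro. Among the compounds shown here, the first measured change at the far end of the thioether chain, hydroxy in place of chloro on a saturated chain carbon bound to a triple-bonded carbon, gives a 1.9-fold higher number from compound 1 to compound 4 (0.27 log units; within the scatter), so with chloro on the aromatic carbon this end of the chain tolerates either group within the scatter. No accompanying data account for any of these steps.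

As far as these compounds go, whether an amine, a methoxy group or bromine on this aromatic carbon would stay within the scatter of chloro remains open. Also open, from the compounds shown here alone, is whether an amine or a carboxylic acid at the chain end, or a longer chain in place of the hydroxybutynyl thioether, would hold the number in this assay.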